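The compounds below may be only part of what the source reports. "The series", "measured", "known", "first", "only" and "open" are said of these compounds alone.

Series notes. Compound 1 `Cc1cc(=O)oc2ccc(OCC(O)CN3CCCCC3)cc12`, compound 2 `Cc1cc(=O)oc2ccc(OCC(O)CN3CCN(C)CC3)cc12` and compound 3 `Cc1cc(=O)oc2ccc(OCC(O)CN3CCN(c4ccccc4)CC3)cc12` differ only in the cyclic amine at the end of the chain. In a functional assay on ileum for antagonist activity at histamine H1 receptor (Cavia porcellus), tested at 1 mg/mL (on this read-out lower numbers stand for an effect already at smaller amounts and higher numbers for an effect only at larger amounts of compound), compound 1 gives 0.0083 ug/mL. In this assay compound 2 gives 0.0081 ug/mL, and compound 3 gives 0.0085 ug/mL. Both changes at the amine leave the number where it was: a 1.0-fold lower number from compound 1 to compound 2 (0.01 log units; within the scatter) and a 1.0-fold higher number from compound 2 to compound 3 (0.02 log units; within the scatter). For the measured compounds named here, compound 3 thus stands within the scatter of compound 1 and of compound 2; no member of the set is separated from another beyond the scatter.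

Compound 4 `COc1ccccc1N1CCN(CC(O)COc2ccc3oc(=O)cc(C)c3c2)CC1` follows compound 3 with one change: methoxy in place of hydrogen on an aromatic carbon. Going by the values given here, no measured step touches the phenyl itself, so the two steps at the amine are the only guide, and both lay within the scatter. On that basis no step beyond the scatter is expected for this change, and the step from compound 3 to compound 4 is estimated as no change at the digits printed from compound 3 to compound 4 (within the scatter). Compound 4 is therefore expected to give about 0.0085 ug/mL in this assay, with a range from 0.004 ug/mL to 0.018 ug/mL to allow for an untested position.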

Compound 4, half-maximal effective concentration: 0.0085 ug/mL
For compound 4 middle estimate and measured number coincide at the digits printed, and the stated range covers the measured number.
By their numbers in this assay, from the lowest: compounds 2, 1, 3 and 4 (each within the scatter of the next).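

In this assay, for the compounds shown here, the first change on the phenyl itself, methoxy in place of hydrogen on an aromatic carbon ortho to a large group, gives no change at the digits printed from compound 3 to compound 4 (within the scatter) and so shows that this carbon takes a substituent without any step beyond the scatter. Read against the methyl form, 2-methoxyphenyl in place of methyl on the ring amine nitrogen gives a 1.0-fold higher number from compound 2 to compound 4 (0.02 log units; within the scatter) and extends the flat picture at that nitrogen to methyl, phenyl and 2-methoxyphenyl, all within the scatter of one another. Nothing at hand gives a reason for this flat response.

The compounds shown leave open whether methoxy at another aromatic carbon of the phenyl, or a chlorine or a hydroxyl at the same carbon, would behave alike. Also open, as far as these compounds go, is whether an open-chain amine such as diethylamine, or a longer chain to the amine, would move the number.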